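Adding an amino group to compound 1

This account rests on a few compounds, and the source may have more. Where it says the series, first, only, none or still open, it means among the compounds named here.

Measured in a functional assay on Hep 3B2 cells (Homo sapiens) for cytotoxicity, read by sulforhodamine B assay, with a stated time of 48 h; a higher number here means a weaker inhibitor of growth, a lower number a stronger inhibitor of growth:
- compound 1 `CCn1cc(-c2nc3ccccc3[nH]2)c(=O)c2cc(F)c(N3CCNCC3)nc21`: 3700 nM
- compound 2 `CCn1cc(-c2nc3ccc([N+](=O)[O-])cc3[nH]2)c(=O)c2cc(F)c(N3CCNC(C)C3)c(F)c21`: 1600 nM

Compound 1 stands at 3700 nM, the higher of the two numbers and so the weaker growth inhibition. Compound 2 stands at 1600 nM, and this gap lies beyond the usual scatter. Within the data shown here, the two compounds differ in more than one place, so the series offers no measured single-change step to serve as a guide.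

The next compound is compound 3 `CCn1cc(-c2nc3ccc(N)cc3[nH]2)c(=O)c2cc(F)c(N3CCNCC3)nc21`, which keeps the core of compound 1 and carries one change: amino in place of hydrogen on an aromatic carbon. This puts amino in place of hydrogen on an aromatic carbon of a six-membered aromatic ring of carbon only.

Among the measured compounds shown here, with only two measured values, the expectation in this assay is weakly grounded. No step beyond the scatter is expected, with a slight lean toward a lower number, and the wide range reflects the lack of direct evidence. The expected step is a 1.5-fold lower number from compound 1 to compound 3 (0.17 log units; within the scatter). For compound 3 the estimated value is 2500 nM, with an expected range of 800 nM to 8000 nM.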

Compound 3, concentration for 50% growth inhibition: > 10000 nM
Compound 3 gave a limit, no number; the forecaster's own chance of this, stated with the estimate: 5%; middle value at least 4.0-fold (0.60 log units) away from the limit.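

In this assay compound 3 gives > 10000 nM, which is a limit of the assay and not a number. Amino in place of hydrogen on an aromatic carbon, on the six-membered aromatic ring of carbon only, brings an at least 2.7-fold higher number from compound 1 to compound 3 (0.43 log units; beyond the scatter); this is the first single-change step in the series, and it shows that this position is not indifferent to substitution, with growth inhibition moving in the weaker direction. The step therefore gives a floor and not a size, and the reading of compound 3 sits at the end of what the assay reports: the limit of > 10000 nM in this assay, at which 1 of the 3 values shown sits.

From the compounds shown here alone, whether the loss belongs to the amino group itself or to any replacement of hydrogen on this aromatic carbon remains open, and a methoxy group or a chlorine at the same place would separate the two readings. The result also rests on one pair alone, so it says nothing yet about how the same change would behave on a core other than that of compound 1.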